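Adding a benzoyl group to a fused ring core

A few compounds are considered here, and "the series" means these few. Any claim that something is new, unique, unknown or untested is made for them only; others in the source may bear on it.

Measured compounds:
compound 1, `O=C(Nc1ccccc1C(F)(F)F)C1CCc2ccccc2N1C(=O)c1ccccc1`: 6340 nM
compound 2, `O=C(Nc1ccccc1O)C1CCc2ccccc2N1`: 2230 nM

Of the compounds shown here, two have been tested in a functional assay on NCI-H23 cells (Homo sapiens) for cytotoxicity, read by sulforhodamine B assay, with a stated time of 72 h; on this read-out lower numbers stand for stronger inhibition of growth and higher numbers for weaker inhibition of growth. Compound 2 gives the lowest of the two numbers, and compound 1 sits at a higher number, a gap that lies beyond the usual scatter. The two structures differ in more than one place, so no single change can be credited for that gap.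

Compound 3, `O=C(Nc1ccccc1O)C1CCc2ccccc2N1C(=O)c1ccccc1`, is compound 2 with one change: benzoyl in place of hydrogen on a nitrogen on an aromatic ring in a ring. Compound 1 also carries a benzoyl group at this place and shows the weaker result, but it differs from compound 2 elsewhere too, so the effect of the benzoyl group alone is not known. A modest weakening is expected, and the step of a 1.6-fold higher number from compound 2 to compound 3 (0.20 log units; within the scatter) is estimated to stay close to the scatter. Compound 3 is expected to give 3500 nM, within a range from 1200 nM to 10000 nM.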

Compound 3, concentration for 50% growth inhibition: 3490 nM
Beside the measured number, compound 3's estimate is 1.0-fold (0.00 log units) above it; measured number inside the range.
By their numbers in this assay, from the lowest: compounds 2, 3 and 1 (each within the scatter of the next, the first and the last beyond it).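

Benzoyl in place of hydrogen on this nitrogen gives a 1.6-fold higher number from compound 2 to compound 3 (0.19 log units; within the scatter) in this assay, so on the hydroxy-bearing compounds this single change does not move the number beyond the scatter. With benzoyl kept on that nitrogen, hydroxy in place of trifluoromethyl on an aromatic carbon gives a 1.8-fold lower number from compound 1 to compound 3 (0.26 log units; within the scatter) and this single change also stays within the scatter. Nothing measured here offers a reason for either step.

The compounds shown leave open whether an acetyl group or a longer alkyl chain on this nitrogen would give a number beyond the scatter from that of compound 2. They also leave open what an amine or a carboxylic acid on the ring of the benzoyl group would do.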